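The compounds below may be only part of what the source reports. "The series", "measured", "known", "first", "only" and "open" are said of these compounds alone.

Measured so far in an ADME assay on BHK-21 cells (Mesocricetus auratus) for cytotoxicity, read by MTT assay, with a stated time of 72 h; on this read-out lower numbers stand for higher toxicity in this test and higher numbers for lower toxicity in this test:
- compound 1 `NS(=O)(=O)c1ccc(N2N=C(c3ccccc3)CC2c2ccccc2F)cc1`: 21000 nM
- compound 2 `Cc1ccc(C2CC(c3ccc(OCc4ccccc4)cc3)=NN2c2ccc(S(N)(=O)=O)cc2)cc1`: 32000 nM

Compound 2 and compound 1 lie within the scatter of each other, so the two numbers show no separation in this assay. Compound 3 `NS(=O)(=O)c1ccc(N2N=C(c3ccc(OCc4ccccc4)cc3)CC2c2ccccc2F)cc1` has not yet been measured. It differs from compound 2 in one place: 2-fluorophenyl in place of 4-methylphenyl on a saturated ring carbon. In words, 2-fluorophenyl stands in place of 4-methylphenyl on a saturated ring carbon.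

Going by the values given here, no measured pair isolates this change, so its size cannot be read directly. The 2-fluorophenyl group already occurs in compound 1, which gives 21000 nM, and that value is within the scatter of compound 2 at 32000 nM. Two compounds are a thin basis, but on these values no step beyond the scatter is expected in this assay, in either direction. The expected change is a 1.2-fold lower number from compound 2 to compound 3 (0.09 log units; within the scatter). The estimated value for compound 3 is 26000 nM, with an expected range of 12000 nM to 60000 nM.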

Compound 3, half-maximal cytotoxic concentration: 90000 nM
Estimate against measurement, compound 3: 3.5-fold (0.54 log units) below; the whole stated range lies below it.
By their numbers in this assay, from the lowest: compounds 1 and 2 (each within the scatter of the next); then compound 3.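

In this assay, the saturated ring carbon next to the ring nitrogen is now shown to matter on the benzyloxy-bearing compounds: 2-fluorophenyl in place of 4-methylphenyl gives a 2.8-fold higher number from compound 2 to compound 3 (0.45 log units; beyond the scatter), a step toward lower toxicity in this test that the first two values could not reveal. With 2-fluorophenyl held in place, benzyloxy in place of hydrogen on an aromatic carbon gives a 4.3-fold higher number from compound 1 to compound 3 (0.63 log units; beyond the scatter), so the second change also moves the read-out in the same direction. Both steps are modest and both end at compound 3, and nothing here accounts for either of them.

The compounds shown do not say whether the step at the saturated ring carbon follows the fluorine, the place of the substituent on the phenyl ring or the loss of the methyl group; 4-fluorophenyl and 2-methylphenyl at that carbon would separate these readings. Going by these compounds, it also remains open whether the step persists without benzyloxy, or with an amine or a carboxylic acid at that aromatic carbon instead.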